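Shrinking the ring on the amide of compound 3

This account rests on a few compounds, and the source may have more. Where it says the series, first, only, none or still open, it means among the compounds named here.

Compound 3 `CS(=O)(=O)c1cnc(O[C@H]2CC[C@H](OC3CCN(C(=O)C4(C(F)(F)F)CCCC4)CC3)CC2)cn1` gives the lowest number of the three compounds measured in a functional assay on isolated protein for agonist activity at Glucose-dependent insulinotropic receptor (Homo sapiens), read by HTRF and cAMP accumulation (a higher number here means a larger maximal response, a lower number a smaller maximal response), where compound 3 reaches 95%. Compound 2 `C[C@H](CF)OC(=O)N1CCC(O[C@H]2CC[C@H](Oc3cnc(S(C)(=O)=O)cn3)CC2)CC1` reaches 108%, and the step is a number 13 percentage points lower from compound 2 to compound 3 (beyond the scatter). Compound 1 `CC1(OC(=O)N2CCC(O[C@H]3CC[C@H](Oc4cnc(S(C)(=O)=O)cn4)CC3)CC2)CC1` reaches 118%, and the step is a number 23 percentage points lower from compound 1 to compound 3 (beyond the scatter). Both steps lie beyond the scatter, so compound 3 stands clearly at the bottom. Compound 4 `CS(=O)(=O)c1cnc(O[C@H]2CC[C@H](OC3CCN(C(=O)C4(C(F)(F)F)CC4)CC3)CC2)cn1` differs from compound 3 in one place: a group of 7 heavy atoms (4 carbon, 3 fluorine; one three-membered non-aromatic ring of carbon only) in place of a group of 9 heavy atoms (6 carbon, 3 fluorine; one five-membered non-aromatic ring of carbon only), on a carbonyl carbon.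

For the measured compounds named here, two measured steps touch the same carbonyl carbon. Each of them replaced a smaller group there by the group of 9 heavy atoms with a five-membered ring, and each lowered the maximal response modestly. The third step, a number 10 percentage points lower from compound 1 to compound 2 (within the scatter), swapped two small groups at that position and stayed within the scatter. Going by the values given here, no measured step trades the five-membered ring for a three-membered one while keeping the trifluoromethyl, so direct guidance is lacking. Because the steps toward the larger group were a number 23 percentage points lower from compound 1 to compound 3 (beyond the scatter) and a number 13 percentage points lower from compound 2 to compound 3 (beyond the scatter), moving back to a smaller group is expected to recover a part of that, giving a small upward step.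

Compound 4 is therefore expected to reach about 103%, within a range of 88% to 118%. This estimate means a step of a number 8 percentage points higher from compound 3 to compound 4 (within the scatter) in this assay.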

Compound 4, largest response reached (Emax), in percent of the reference or control that the assay uses: 107%
Estimate against measurement, compound 4: 4 percentage points below; the measured number falls inside the stated range.
By their numbers in this assay, from the lowest: compound 3; then compounds 4, 2 and 1 (each within the scatter of the next, the first and the last beyond it).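

In this assay, for the compounds shown here, the step of a number 12 percentage points higher from compound 3 to compound 4 (beyond the scatter) is the first direct comparison of ring size with the trifluoromethyl held in place, and it shows that ring size alone changes the maximal response by more than the scatter. Set against the groups that hold an oxygen on the carbonyl carbon, 1-(trifluoromethyl)cyclopropyl gives a number 1 percentage points lower from compound 2 to compound 4 (within the scatter), so compound 2 and compound 4 cannot be told apart, while a number 11 percentage points lower from compound 1 to compound 4 (beyond the scatter) leaves compound 4 clearly short of compound 1, which carries the (1-methylcyclopropyl)oxy group. Nothing available here explains why these steps occur.

With only a three-membered and a five-membered ring shown, it remains open whether the response changes steadily with ring size, which 1-(trifluoromethyl)cyclobutyl, with its four-membered ring, could test. From the compounds shown here alone, both rings also carry the trifluoromethyl, so what that group contributes remains open too, and 1-methylcyclopropyl placed directly on the carbonyl carbon would separate its part from that of the ring.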